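Swapping the distal para group: ester to dimethylaminomethyl

The source may hold more compounds than are shown below. What is called first, only, known or untested is meant among the compounds shown, and "the series" means these compounds.

Measured compounds:
Compound 1 `CC[C@H](C)[C@H](N)CN(C(=O)[C@@H]1C[C@H]1c1ccccc1)c1ccc(-c2ccc(C(C)(C)C)cc2)cc1`: 750 nM
Compound 2 `CC[C@H](C)[C@H](N)CN(C(=O)[C@@H]1C[C@H]1c1ccccc1)c1ccc(-c2ccc(Oc3ccccc3)cc2)cc1`: 94 nM
Compound 3 `CCOC(=O)c1ccc(-c2ccc(N(C[C@@H](N)[C@@H](C)CC)C(=O)[C@@H]3C[C@H]3c3ccccc3)cc2)cc1`: 260 nM

All three share one core and differ only at one aromatic carbon of the outer ring. In a functional assay for agonist activity at G protein-coupled receptor 88 (Homo sapiens), read by HTRF and cAMP accumulation (a lower number here means that less compound is needed, a higher number that more compound is needed for the effect), compound 3 gives 260 nM, the second highest of the three numbers, sitting between compound 2 and compound 1. Compound 4 `CC[C@H](C)[C@H](N)CN(C(=O)[C@@H]1C[C@H]1c1ccccc1)c1ccc(-c2ccc(CN(C)C)cc2)cc1` carries (dimethylamino)methyl in place of ethoxycarbonyl on an aromatic carbon. Among the compounds with values here, no measured step covers this exact exchange. The steps that exist all concern the same position and were modest: an 8.0-fold lower number from compound 1 to compound 2 (0.90 log units; beyond the scatter), a 2.9-fold lower number from compound 1 to compound 3 (0.46 log units; beyond the scatter) and a 2.8-fold higher number from compound 2 to compound 3 (0.44 log units; beyond the scatter). On that basis a step of comparable size in this assay is expected, with its direction uncertain. Compound 4 is therefore estimated at 350 nM, within 110 nM to 1100 nM. This expected change corresponds to a 1.3-fold higher number from compound 3 to compound 4 (0.13 log units; within the scatter).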

Compound 4, half-maximal effective concentration: 460 nM
Compound 4: the middle estimate sits 1.3-fold (0.12 log units) below what was measured; the range from low to high includes it.
By their numbers in this assay, from the lowest: compound 2; then compounds 3, 4 and 1 (each within the scatter of the next, the first and the last beyond it).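

At this aromatic carbon the only nitrogen-bearing group shown, (dimethylamino)methyl, leaves compound 4 level with the ethoxycarbonyl and tert-butyl compounds in this assay with a 1.8-fold higher number from compound 3 to compound 4 (0.25 log units; within the scatter) and a 1.6-fold lower number from compound 1 to compound 4 (0.21 log units; within the scatter) both inside the scatter. Only phenoxy stands clear of it, with a 4.9-fold higher number from compound 2 to compound 4 (0.69 log units; beyond the scatter) beyond the scatter. Nothing measured here bears on why these steps have this size. The compounds shown leave open how a primary amine or a carboxylic acid would behave at this carbon. They also leave open whether a longer chain carrying the dimethylamino group would differ.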